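A few compounds are considered here, and "the series" means these few. Any claim that something is new, unique, unknown or untested is made for them only; others in the source may bear on it.

Compound 1 `CN1C/C(=C\c2ccncc2)C(=O)/C(=C/c2ccccc2C(F)(F)F)C1` gives 3300 nM
Compound 2 `O=C1/C(=C/c2cccnc2)CN(S(=O)(=O)c2ccccc2)C/C1=C\c1ccccc1F` gives 8210 nM

In a functional assay on HepG2 cells (Homo sapiens) for cytotoxicity, read by MTT assay, with a stated time of 24 h (on this read-out lower numbers stand for stronger inhibition and higher numbers for weaker inhibition), compound 2 has the higher of the two numbers, so it is the weaker inhibitor of this pair. Compound 3 `O=C1/C(=C/c2cccnc2)CN(S(=O)(=O)c2ccc(Br)cc2)C/C1=C\c1ccccc1F` differs from compound 2 in one place, with bromo in place of hydrogen on an aromatic carbon, turning phenylsulfonyl into (4-bromophenyl)sulfonyl. Among the measured compounds shown here, no measured pair shows this change, so the estimate stays close to compound 2 (8210 nM). A small move toward a lower number is expected, probably within the scatter: the estimated step is a 1.5-fold lower number from compound 2 to compound 3 (0.17 log units; within the scatter) in this assay. For compound 3 the estimated value is 5500 nM (range 2000 nM to 14000 nM).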

Compound 3, half-maximal inhibitory concentration: 8700 nM
Beside the measured number, compound 3's estimate is 1.6-fold (0.20 log units) below it, and the stated range covers the measured number.
By their numbers in this assay, from the lowest: compound 1; then compounds 2 and 3 (each within the scatter of the next).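

Turning phenyl into 4-bromophenyl gives a 1.1-fold higher number from compound 2 to compound 3 (0.03 log units; within the scatter) in this assay. Among the compounds shown here, this is the only one-place comparison here, and it shows that a single bromine atom at this place on the sulfonyl-bound ring leaves the number within the usual scatter. No measurement shown here offers an explanation for this result. As far as these compounds go, whether an amine, a methoxy group or a carboxylic acid at the same place would also stay within the scatter remains open, as does the outcome of moving bromo elsewhere on this ring.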